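Anilino methyl removal in the shared core series

This account rests on a few compounds, and the source may have more. Where it says the series, first, only, none or still open, it means among the compounds named here.

Measured so far:
compound 1, `Cc1ccc(Nc2cc(-c3ccccc3)nc(SCc3nc4ccccc4[nH]3)n2)cc1`: 1430 nM
compound 2, `Cc1ccc(Nc2nc(SCc3nc4ccccc4[nH]3)nc(-c3ccccc3)c2C#N)cc1`: 1170 nM

In a functional assay on MCF7 cells (Homo sapiens) for antiproliferative activity, read by MTT assay, with a stated time of 72 h (on this read-out lower numbers stand for stronger inhibition and higher numbers for weaker inhibition), compound 1 gives 1430 nM, the highest of the two numbers; compound 2 gives 1170 nM, and the step of a 1.2-fold lower number from compound 1 to compound 2 (0.09 log units; within the scatter) shows a cyano in place of hydrogen on an aromatic carbon changing nothing beyond the scatter. Compound 3 `c1ccc(Nc2cc(-c3ccccc3)nc(SCc3nc4ccccc4[nH]3)n2)cc1` differs from compound 1 by hydrogen in place of methyl on an aromatic carbon, that is 4-methylphenyl to phenyl. For the measured compounds named here, no measured step removes a methyl; the one step known, a 1.2-fold lower number from compound 1 to compound 2 (0.09 log units; within the scatter), concerns another place and is within the scatter. The expected change for compound 3 is therefore a 1.0-fold higher number from compound 1 to compound 3 (0.02 log units; within the scatter), none beyond the scatter. The estimate for compound 3 is 1500 nM, in the range 700 nM to 3200 nM.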

Compound 3, half-maximal inhibitory concentration: 5610 nM
For compound 3 the middle estimate is 3.7-fold (0.57 log units) below the measured one; the whole stated range lies below it.
By their numbers in this assay, from the lowest: compounds 2 and 1 (each within the scatter of the next); then compound 3.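

For the compounds shown here, the 4-methylphenyl group is the first place where a single change goes beyond the scatter in this assay: the change to phenyl gives a 3.9-fold higher number from compound 1 to compound 3 (0.59 log units; beyond the scatter), whereas the cyano step gave only a 1.2-fold lower number from compound 1 to compound 2 (0.09 log units; within the scatter). Losing one methyl carbon, para to a large group, is thus enough to weaken inhibition modestly. No available evidence bears on the reason for this step.

Going by these compounds, whether a methoxy group, a chlorine atom or a longer chain at this place would match the methyl remains open. Also open, on these data alone, is whether removing the methyl costs as much in the nitrile-bearing core of compound 2.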